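Extending a Chain: From Compound 3 to Compound 4

This account rests on a few compounds, and the source may have more. Where it says the series, first, only, none or still open, it means among the compounds named here.

Three compounds share one core. Compound 1 `O=C1C=C[C@]2(O)CCO[C@@H]2C1` carries a hydrogen on an oxygen on a saturated carbon, and in a functional assay on HeLa S3 cells (Homo sapiens) for cytotoxicity (on this read-out lower numbers stand for stronger inhibition and higher numbers for weaker inhibition), compound 1 gives 2.8 ug/mL. Compound 2 `CC(=O)O[C@]12C=CC(=O)C[C@H]1OCC2` has acetyl in that place, and in this assay compound 2 gives 4.1 ug/mL. Compound 3 `CCCC(=O)O[C@]12C=CC(=O)C[C@H]1OCC2` has propylcarbonyl there, and in this assay compound 3 gives 2.7 ug/mL. Going by the values given here, of the three numbers, the one for compound 3 is the lowest, yet the gaps are small: a 1.0-fold lower number from compound 1 to compound 3 (0.02 log units; within the scatter) and a 1.5-fold lower number from compound 2 to compound 3 (0.18 log units; within the scatter), so none of the three can be set apart from the others.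

Compound 4 `CCCCCC(=O)O[C@]12C=CC(=O)C[C@H]1OCC2` has not yet been measured. It differs from compound 3 in one place: ethyl in place of hydrogen on a saturated chain carbon, three bonds along the chain from a carbonyl carbon. The closest guide is the chain growth already seen, a 1.5-fold lower number from compound 2 to compound 3 (0.18 log units; within the scatter), which changed nothing beyond the scatter; likewise a 1.5-fold higher number from compound 1 to compound 2 (0.17 log units; within the scatter) and a 1.0-fold lower number from compound 1 to compound 3 (0.02 log units; within the scatter) stayed within it. Three such changes left the read-out essentially where it was, so the expected step, a 1.0-fold higher number from compound 3 to compound 4 (0.02 log units; within the scatter), is not thought to go beyond the scatter. Compound 4 is therefore estimated at 2.8 ug/mL, with a range from 1.3 ug/mL to 6 ug/mL.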

Compound 4, half-maximal inhibitory concentration: 1.8 ug/mL
Beside the measured number, compound 4's estimate is 1.6-fold (0.19 log units) above it; the range from low to high includes it.
By their numbers in this assay, from the lowest: compounds 4, 3, 1 and 2 (each within the scatter of the next, the first and the last beyond it).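

In this assay, ethyl in place of hydrogen on a saturated chain carbon, three bonds along the chain from a carbonyl carbon, gives a 1.5-fold lower number from compound 3 to compound 4 (0.18 log units; within the scatter) and so, taken alone, this extension cannot be told apart from the differences seen between repeated measurements. The new information comes from setting the pentyl chain of compound 4 against the methyl of compound 2: this longer chain gives a 2.3-fold lower number from compound 2 to compound 4 (0.36 log units; beyond the scatter) and this is the first step among these compounds to pass beyond the scatter, though only modestly, with no sign so far that the position penalises a chain of this length. No measurement offered here explains why the read-out responds this way.

The compounds shown leave open whether a longer chain, such as octyl, would carry the number further in the same direction or whether the trend would stop. They also leave open how the read-out would respond to an amine or a carboxylic acid carried on the chain at this position.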